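The source may report more compounds than this note shows. Statements on the series, on what has been measured and on what is new or still open speak of the compounds shown alone.

Compounds measured so far in a physicochemical assay for solubility, using the shake flask method, in simulated intestinal fluid, measured as kinetic solubility, with a stated time of 2 h, at 25 degrees C, at pH 6.5; on this read-out lower numbers stand for lower solubility and higher numbers for higher solubility:
- compound 1 `Cc1noc(-c2nc(C)c3c(c2N)C(=O)N(Cc2ccc(-n4cccn4)cc2)C3=O)n1`, reported only as a limit, < 5000 nM
- compound 2 `Cc1noc(-c2nc(C)c3c(c2N)C(=O)N(CC2CCNCC2)C3=O)n1`, 160000 nM
- compound 3 `Cc1noc(-c2nc(C)c3c(c2N)C(=O)N(Cc2ccccc2C(F)(F)F)C3=O)n1`, reported only as a limit, < 5000 nM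

Compound 3 stands at the floor of this assay, where only a bound and no number is given; the same holds for (the limit of < 5000 nM in this assay, at which 2 of the 3 values shown sit). Among the compounds with values here, the one measured step across this position is an at least 32-fold lower number from compound 2 to compound 3 (1.50 log units; beyond the scatter). Compound 4 `Cc1noc(-c2nc(C)c3c(c2N)C(=O)N(Cc2ccc(CO)cc2)C3=O)n1` differs from compound 3 in that (4-(hydroxymethyl)phenyl in place of 2-(trifluoromethyl)phenyl on a saturated chain carbon bound to an amide-type nitrogen in a ring). Within the data shown here, no measured step covers this pair, so the step from compound 2 to compound 3 gives only the scale at which this position can move. For compound 4 a reading clearing the limit seen for compound 3 is expected, though a limit again cannot be excluded. The estimate for compound 4 is 20000 nM, between 5000 nM and 80000 nM, an expected step of an at least 4.0-fold higher number from compound 3 to compound 4 (0.60 log units; beyond the scatter).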

Compound 4, solubility: < 5000 nM
Compound 4 ended at the assay's limit; the forecaster's own chance of this, stated with the estimate: 30%; at least 4.0-fold (0.60 log units) between middle value and limit.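

In this assay, 4-(hydroxymethyl)phenyl brings one hydrogen-bond donor and one acceptor that 2-(trifluoromethyl)phenyl lacks, yet compound 4 is still reported only as a limit, < 5000 nM. Piperidin-4-yl remains the only group at this place with a readable number, and replacing it with 4-(hydroxymethyl)phenyl gives an at least 32-fold lower number from compound 2 to compound 4 (1.50 log units; beyond the scatter). The steps among compound 1, compound 3 and compound 4 cannot be read, as all three stand at one bound: the limit of < 5000 nM in this assay, at which 3 of the 4 values shown sit.

As far as these compounds go, it remains open whether a phenyl ring carrying an amine or a carboxylic acid would give a readable number at this place. From the compounds shown here alone, it also remains open whether a cyclohexyl group, which lacks the ring nitrogen of piperidin-4-yl, would do so.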